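Propylamino in place of methoxy on the shared core

The source may report more compounds than this note shows. Statements on the series, on what has been measured and on what is new or still open speak of the compounds shown alone.

In a functional assay on CCRF-CEM cells (Homo sapiens) (on this read-out higher numbers stand for weaker inhibition and lower numbers for stronger inhibition), compound 1 `OC[C@H]1C[C@@H](Cn2cnc3c(O)ncnc32)c2ccccc21` gives 24 ug/mL, and compound 2 `COc1ncnc2c1ncn2C[C@@H]1C[C@H](CO)c2ccccc21` gives 24 ug/mL. The two stand level at the digits shown, so compound 2 offers no gain or loss over compound 1 as a starting point.

The next structure, compound 3 `CCCNc1ncnc2c1ncn2C[C@@H]1C[C@H](CO)c2ccccc21`, carries this change: propylamino in place of methoxy on an aromatic carbon. In words, propylamino stands in place of methoxy on an aromatic carbon.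

Within the data shown here, only one measured step bears on this, no change at the digits printed from compound 1 to compound 2 (within the scatter), with methyl in place of hydrogen on an oxygen on an aromatic ring. That step lies within the scatter, and it concerns the group on the same aromatic carbon. It is thin evidence, since no amino group at this place has been measured and the propyl chain is new to the series.

With that single flat step as the guide, the expected move in this assay is small, with no firm direction and nothing clearly beyond the scatter: a 1.2-fold lower number from compound 2 to compound 3 (0.08 log units; within the scatter) is the estimated step.

For compound 3 the estimated value is 20 ug/mL, with an expected range of 8 ug/mL to 50 ug/mL.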

Compound 3, half-maximal inhibitory concentration: 24 ug/mL
For compound 3 the middle estimate is 1.2-fold (0.08 log units) below the measured one; low and high end bracket the measured number.
By their numbers in this assay, from the lowest: compounds 1, 2 and 3 (each within the scatter of the next).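

In this assay propylamino in place of methoxy on this aromatic carbon gives no change at the digits printed from compound 2 to compound 3 (within the scatter) and propylamino in place of hydroxy on the same carbon gives no change at the digits printed from compound 1 to compound 3 (within the scatter) in this series. Among these compounds, the position, until now seen only with hydroxy and methoxy, thus also accepts a nitrogen-linked chain that brings in a hydrogen-bond donor, and the read-out does not separate the three groups. Nothing at hand accounts for this flat result.

Still open, from the compounds shown here alone, is whether any group on this carbon can move the number beyond the scatter: an unsubstituted amino group, a longer chain such as hexylamino, a cyclic amine such as piperidine or a chloro substituent would each test this further. Going by these compounds, the hydroxymethyl group on the shared core also remains open, since all three compounds carry it, and a carboxylic acid or a methyl ether there would show whether that part of the structure has more influence on the read-out than the aromatic carbon examined so far.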